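The compounds below may be only part of what the source reports. "The series", "measured", "known", "first", "only" and "open" are said of these compounds alone.

In a functional assay on A2780 cells (Homo sapiens) for inhibition, read by sulforhodamine B assay, with a stated time of 72 h; on this read-out higher numbers stand for weaker inhibition and lower numbers for stronger inhibition:

- Compound 1 `O=C(NCc1ccc(S(=O)(=O)c2ccccc2)cc1)c1cc2ccncc2s1`: 14 nM
- Compound 2 `Cn1c(C(=O)NCc2ccc(S(=O)(=O)c3ccccc3)cc2)cc2ccncc21`: > 10000 nM

For the measured compounds named here, compound 1 holds the only actual number in this small set. Compound 2 gives > 10000 nM, which is a limit of this assay and not a number.

Compound 3 `O=C(NCc1ccc(S(=O)(=O)c2ccccc2)cc1)c1ccc2nncn2c1` has not yet been measured. It departs from compound 1 on the carbonyl carbon: a group of 9 heavy atoms (6 carbon, 3 nitrogen; one five-membered aromatic ring with 3 hetero atoms, one six-membered aromatic ring with 1 hetero atom) in place of a group of 9 heavy atoms (7 carbon, 1 nitrogen, 1 sulfur; one five-membered aromatic ring with 1 hetero atom, one six-membered aromatic ring with 1 hetero atom), on a carbonyl carbon. Going by the values given here, no measured step covers this exchange, so any expectation for it is loose. A loss of inhibition in this assay well beyond the usual scatter is expected, though its size is uncertain. That expectation rests on compound 2, whose reading of > 10000 nM is a limit and shows how far this series can fall. The expected change is a 57-fold higher number from compound 1 to compound 3 (1.76 log units; beyond the scatter). For compound 3 the estimated value is 800 nM, with an expected range of 40 nM to 10000 nM.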

Compound 3, half-maximal inhibitory concentration: > 10000 nM
Compound 3: no number, only a limit; the forecaster's own chance of this, stated with the estimate: 30%; middle value at least 12-fold (1.09 log units) from the limit.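

In this assay, for the compounds shown here, exchanging only the group on the carbonyl carbon gives an at least 710-fold higher number from compound 1 to compound 3 (2.85 log units; beyond the scatter), the first measured step at this position, and it shows that the amide-type nitrogen side of the molecule cannot carry inhibition by itself. The leaving and entering groups both have 9 heavy atoms, one five-membered aromatic ring and one six-membered aromatic ring, so keeping those counts does not keep the inhibition. Compound 3 sits at a limit and not at a number, so the full size of the step cannot be read: the limit of > 10000 nM in this assay, at which 2 of the 3 values shown sit.

The compounds shown do not tell which part of the exchange matters, the sulfur leaving, the added ring nitrogens or the extra hydrogen-bond acceptor. Going by these compounds, whether a plain phenyl ring on the carbonyl carbon would retain any inhibition also remains open.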